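The source may report more compounds than this note shows. Statements on the series, on what has been measured and on what is new or still open speak of the compounds shown alone.

In a functional assay on KB cells (Homo sapiens) for cytotoxicity (on this read-out higher numbers stand for weaker inhibition and lower numbers for stronger inhibition), compound 1 (`COc1ccc(S(=O)(=O)N2CCc3cccc(NC(=O)C(C)(C)C)c32)cc1`) gives 359 nM and compound 2 (`COc1ccc(S(=O)(=O)N2CCc3cccc(NS(=O)(=O)c4ccc(F)cc4)c32)cc1`) gives 1200 nM as the higher of the two numbers. Compound 3 (`COc1ccc(S(=O)(=O)N2CCc3cccc(NC(=O)c4cccs4)c32)cc1`) has (thiophen-2-yl)carbonyl in place of (4-fluorophenyl)sulfonyl on a nitrogen on an aromatic ring. Among the measured compounds shown here, the one measured step on that nitrogen went from a carbonyl to a sulfonyl and was modest (a 3.3-fold higher number from compound 1 to compound 2 (0.52 log units; beyond the scatter)). For the measured compounds named here, compound 3 again has a carbonyl on that nitrogen, like compound 1 at 359 nM and so a step of similar or somewhat larger size toward lower numbers is expected in this assay with only this comparison as support. The expected step (a 4.8-fold lower number from compound 2 to compound 3 (0.68 log units; beyond the scatter)) is correspondingly uncertain. Compound 3 is estimated at 250 nM (expected range 60 nM to 900 nM).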

Compound 3, half-maximal inhibitory concentration: 47 nM
Compound 3: middle estimate off by 5.3-fold (0.73 log units), on the high side, outside the stated range (below it).
By their numbers in this assay, from the lowest: compound 3; then compound 1; then compound 2.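

In this assay, the group on the nitrogen on the aromatic ring matters beyond the choice of carbonyl or sulfonyl: (thiophen-2-yl)carbonyl in place of (4-fluorophenyl)sulfonyl gives a 26-fold lower number from compound 2 to compound 3 (1.41 log units; beyond the scatter). With the carbonyl kept, thiophen-2-yl in place of tert-butyl still gives a 7.6-fold lower number from compound 1 to compound 3 (0.88 log units; beyond the scatter), so the group on the carbonyl carbon also moves the number. No measurement here accounts for either step.

Open, as far as these compounds go, is whether this gain is specific to thiophen-2-yl or would also hold for phenyl or furan-2-yl on the carbonyl carbon. A (thiophen-2-yl)sulfonyl group would separate the effect of the linking group from that of the ring in the step from compound 2.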